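Replacing the nitro group of compound 3 with a hydroxy group

The source may hold more compounds than are shown below. What is called first, only, known or untested is meant among the compounds shown, and "the series" means these compounds.

Measured compounds:
- compound 1, `CCOc1ccc(/C=N/NC(=O)COc2cccc3ccccc23)cc1O`: 100 ug/mL
- compound 2, `C/C(=N\NC(=O)COc1cccc2ccccc12)c1ccccc1`: 20 ug/mL
- compound 3, `C/C(=N\NC(=O)COc1cccc2ccccc12)c1ccc([N+](=O)[O-])cc1`: 100 ug/mL

In an ADME assay on HEL cells (Homo sapiens) for cytotoxicity (on this read-out lower numbers stand for higher toxicity in this test and higher numbers for lower toxicity in this test), compound 3 gives 100 ug/mL. Among the compounds with values here, that value sits level with compound 1, and together these two are the highest of the three numbers; the only compound set apart is compound 2, whose number is the lowest.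

Within the data shown here, the single measured step that touches the shared core is a 5.0-fold higher number from compound 2 to compound 3 (0.70 log units; beyond the scatter), where a nitro group replaced a hydrogen on the aromatic ring.

Compound 4, `C/C(=N\NC(=O)COc1cccc2ccccc12)c1ccc(O)cc1`, has not yet been tested. It differs from compound 3 in one place: hydroxy in place of nitro on an aromatic carbon.

Among the measured compounds shown here, no measured step swaps a nitro group for a hydroxy group, so the size of this change is open. What is known is that the ring without a substituent (compound 2) gave the lowest number, while the nitro-bearing ring (compound 3) and the hydroxy-bearing ring of compound 1 both reached the top of the range. A hydroxy group on the ring of compound 4 is therefore expected to leave the number somewhere between those extremes, with the step of a 1.7-fold lower number from compound 3 to compound 4 (0.22 log units; within the scatter) expected to be small or none beyond the scatter. The estimate for compound 4 is 60 ug/mL, within 20 ug/mL to 100 ug/mL.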

Compound 4, minimum cytotoxic concentration: 20 ug/mL
Compound 4: the middle estimate sits 3.0-fold (0.48 log units) above what was measured; low and high end bracket the measured number.
By their numbers in this assay, from the lowest: compounds 2 and 4 (each within the scatter of the next); then compounds 1 and 3 (each within the scatter of the next).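

In this assay the change from 4-nitrophenyl to 4-hydroxyphenyl gives a 5.0-fold lower number from compound 3 to compound 4 (0.70 log units; beyond the scatter), so the high number of compound 3 does not extend to every group placed on this aromatic carbon. Putting hydroxy in place of hydrogen on the same carbon gives no change at the digits printed from compound 2 to compound 4 (within the scatter), so the ring with hydroxy and the ring with no added group read alike in this series, and of the three groups compared on this core, only nitro stands apart, with a number that marks lower toxicity in this test. Nothing available here accounts for this difference between nitro and hydroxy.

On these data alone, with only hydrogen, hydroxy and nitro compared at this position, it remains open whether the higher number belongs to nitro alone or would also appear with another group on the same carbon, such as a nitrile, a carboxylic acid, an amine or a methoxy group. Also open, as far as these compounds go, is whether a nitro group would keep its number on a different carbon of this ring.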